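Swapping a Sulfur-Bearing Chain End for Carbon in a Guinea Pig Assay

This account rests on a few compounds, and the source may have more. Where it says the series, first, only, none or still open, it means among the compounds named here.

Compound 1, `CCCCC[C@](C)(O)/C=C/C1CCC(=O)[C@@H]1CCCCSCC(=O)O`: 0.0054 mg/kg
Compound 2, `CCCCC(C)(C)[C@H](O)/C=C/C1CCC(=O)[C@@H]1CCCCSCC(=O)O`: 0.0523 mg/kg
Compound 3, `CCCCC[C@](C)(O)/C=C/C1CCC(=O)[C@@H]1CCCCCCC(=O)O`: 0.00699 mg/kg

Three compounds were measured in a functional assay on the whole organism (strain Hartley) for inhibition, with Cavia porcellus as the target, with stated times of 2 min and 15 min; on this read-out lower numbers stand for an effect already at smaller amounts and higher numbers for an effect only at larger amounts of compound. Compound 1 gives 0.0054 mg/kg, compound 3 gives 0.00699 mg/kg, and compound 2 gives 0.0523 mg/kg, the highest of the three numbers, with both of its gaps to the others beyond the scatter. Compound 1 and compound 3 share a core and differ by 2-carboxyethyl in place of (carboxymethyl)sulfanyl on a saturated chain carbon, four bonds along the chain from a saturated ring carbon; this change gives a 1.3-fold higher number from compound 1 to compound 3 (0.11 log units; within the scatter). How the core of compound 2 differs from that of compound 1 is not broken down here.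

Compound 4, `CCCCC(C)(C)[C@H](O)/C=C/C1CCC(=O)[C@@H]1CCCCCCC(=O)O`, has not yet been measured in this assay. It stands to compound 2 as compound 3 stands to compound 1, differing by 2-carboxyethyl in place of (carboxymethyl)sulfanyl on a saturated chain carbon, four bonds along the chain from a saturated ring carbon, the same change at the same place. Because the measured step of a 1.3-fold higher number from compound 1 to compound 3 (0.11 log units; within the scatter) lay within the scatter, the step from compound 2 to compound 4 is expected to be of similar small size, a 1.2-fold higher number from compound 2 to compound 4 (0.09 log units; within the scatter). Compound 4 is therefore estimated at 0.065 mg/kg, with a likely range from 0.03 mg/kg to 0.14 mg/kg.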

Compound 4, dose for half-maximal effect: 0.0259 mg/kg
Compound 4: middle estimate off by 2.5-fold (0.40 log units), on the high side; measured number below the stated range.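

In this assay, the swap of (carboxymethyl)sulfanyl for 2-carboxyethyl, now read on a second core, gives a 2.0-fold lower number from compound 2 to compound 4 (0.31 log units; beyond the scatter). Set beside the earlier step on the other core, this step does not differ from it by more than two such steps scatter, so the change can be said to carry from one core to the other as far as these numbers can resolve: the same change on two cores in this assay, a 1.3-fold higher number (0.11 log units; within the scatter) from compound 1 to compound 3 and a 2.0-fold lower number (0.31 log units; beyond the scatter) from compound 2 to compound 4, 2.6-fold (0.42 log units) apart, within the scatter of two such steps This does not show that the change behaves alike on every core of the series, since it rests on two cores in one assay, and it does not settle whether the modest gain on the second core is real or whether the change has any effect at all.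

The compounds shown leave open how an ether oxygen or a sulfone in place of the sulfur would read on either core. They also leave open what a longer chain or a methyl ester at the chain end would do.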